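Heteroaryl carbonyl swaps on the shared core

The source may report more compounds than this note shows. Statements on the series, on what has been measured and on what is new or still open speak of the compounds shown alone.

Within the data shown here, in an assay on HEK293 cells for agonist activity at Toll-like receptor 8 (Homo sapiens), read by a luciferase reporter, with a stated time of 6 h (on this read-out lower numbers stand for an effect already at smaller amounts and higher numbers for an effect only at larger amounts of compound), compound 2 `CCCCNc1nc(N)nc2c1CN(C(=O)c1csnn1)CC2` gives 0.1 uM, the lower of the two numbers so far; compound 1 `CCCCNc1nc(N)nc2c1CN(C(=O)c1cscn1)CC2` gives 0.5 uM. Among the measured compounds shown here, the only measured step is a 5.0-fold lower number from compound 1 to compound 2 (0.70 log units; beyond the scatter), a single exchange of one five-membered ring on the carbonyl carbon. Compound 3 `CCCCNc1nc(N)nc2c1CN(C(=O)c1cocn1)CC2` carries the next such exchange, (1,3-oxazol-4-yl in place of 1,2,3-thiadiazol-4-yl on a carbonyl carbon). With just that one step for guidance, a return toward the number of compound 1 seems the more likely outcome, so compound 3 is expected to show a modest rise, a 4.0-fold higher number from compound 2 to compound 3 (0.60 log units; beyond the scatter). The estimate for compound 3 is 0.4 uM, within 0.15 uM to 1.5 uM.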

Compound 3, minimum effective concentration: 0.2 uM
Estimate against measurement, compound 3: 2.0-fold (0.30 log units) above; the range from low to high includes it.
By their numbers in this assay, from the lowest: compounds 2 and 3 (each within the scatter of the next); then compound 1.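

At this carbonyl carbon, 1,3-oxazol-4-yl in place of 1,2,3-thiadiazol-4-yl leaves the two compounds within the scatter (a 2.0-fold higher number from compound 2 to compound 3 (0.30 log units; within the scatter)), although the two rings differ in their hetero atoms. 1,3-oxazol-4-yl in place of 1,3-thiazol-4-yl gives a step beyond the scatter (a 2.5-fold lower number from compound 1 to compound 3 (0.40 log units; beyond the scatter)), so of the three rings only 1,3-thiazol-4-yl stands apart. No evidence is available to explain these readings.

Still open, on these data alone, is how a six-membered ring such as pyridin-2-yl or a saturated group such as cyclopropyl would read on this carbonyl carbon.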